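This account rests on a few compounds, and the source may have more. Where it says the series, first, only, none or still open, it means among the compounds named here.

Measured compounds in an ADME assay on HEK293 cells (Homo sapiens) for cytotoxicity, read by MTT assay, with a stated time of 48 h; a higher number here means a weaker inhibitor, a lower number a stronger inhibitor:
Compound 1 `COc1cc(NC(=O)c2cc(C(F)(F)F)cc(C(F)(F)F)c2)ccc1NS(C)(=O)=O` gives 42000 nM in this assay.
Compound 2 `CCS(=O)(=O)Nc1ccc(NC(=O)c2cc(C(F)(F)F)cc(C(F)(F)F)c2)cc1OC` gives > 250000 nM in this assay, which is a limit of the assay and not a number.
Compound 3 `COc1cc(NC(=O)c2cc(C(F)(F)F)cc(C(F)(F)F)c2)ccc1NS(=O)(=O)C(F)(F)F` gives > 250000 nM in this assay, again a limit of the assay rather than a number.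

Compound 3 therefore stands at the upper edge of what this assay reports, on (the limit of > 250000 nM in this assay, at which 2 of the 3 values shown sit). Compound 1 is the only one of the three with an actual number.

The step to compound 4 `O=C(Nc1ccc(NS(=O)(=O)C(F)(F)F)c(Cl)c1)c1cc(C(F)(F)F)cc(C(F)(F)F)c1` is chloro in place of methoxy on an aromatic carbon. All measured steps in this set concern the group on the sulfonyl sulfur instead: an at least 5.9-fold higher number from compound 1 to compound 2 (0.77 log units; beyond the scatter) and an at least 5.9-fold higher number from compound 1 to compound 3 (0.77 log units; beyond the scatter) both move away from the number of compound 1 onto the limit, while a step that the two limits leave unreadable from compound 2 to compound 3. For the measured compounds named here, none of them changes the substituent on the aromatic ring of the shared core, so no measured step bears directly on the swap of methoxy for chloro.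

With compound 3 already at the limit, the expected outcome for compound 4 in this assay is that it stays there, and the step of a number no higher from compound 3 to compound 4 (the limit leaves the size open) is expected to show nothing readable beyond the scatter. Compound 4 is estimated at 250000 nM, within 80000 nM to 800000 nM, most likely reported again as a limit.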

Compound 4, half-maximal inhibitory concentration: > 250000 nM
Compound 4 gave a limit, no number; the forecaster's own chance of this, stated with the estimate: 70%; the middle value lies on the limit itself.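

Compound 3 and compound 4 both sit on a limit of this assay and not on a number, so the swap of chloro for methoxy gives no readable step: the limit of > 250000 nM in this assay, at which 3 of the 4 values shown sit.

The compounds shown leave open what chloro in place of methoxy does in this assay, and how far apart compound 2, compound 3 and compound 4 lie.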